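Lengthening the chain to the charged group

The source may report more compounds than this note shows. Statements on the series, on what has been measured and on what is new or still open speak of the compounds shown alone.

Of the compounds shown here, three sharing one core have been measured so far. Compound 1 `O=c1c(OCCO)c(-c2ccc(O)c(O)c2)oc2ccccc12` is tested in a functional assay for inhibition, with Rattus norvegicus as the target, using microsomes (a higher number here means a weaker inhibitor, a lower number a stronger inhibitor), and gives 600 nM. Compound 2 `CN(C)CCCOc1c(-c2ccc(O)c(O)c2)oc2ccccc2c1=O` gives 1000 nM in this assay, and compound 3 `C[N+](C)(C)CCCOc1c(-c2ccc(O)c(O)c2)oc2ccccc2c1=O` gives 1200 nM. Compound 3 has the highest of the three numbers, yet each neighbour sits within the usual scatter: a 2.0-fold higher number from compound 1 to compound 3 (0.30 log units; within the scatter), and a 1.2-fold higher number from compound 2 to compound 3 (0.08 log units; within the scatter).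

Compound 4 `C[N+](C)(C)CCCCCCOc1c(-c2ccc(O)c(O)c2)oc2ccccc2c1=O` is not yet measured. Compared with compound 3 the change is a group of 7 heavy atoms (6 carbon, 1 nitrogen; no ring) in place of a group of 4 heavy atoms (3 carbon, 1 nitrogen; no ring), on a saturated chain carbon, three bonds along the chain from an oxygen on an aromatic ring. Only the chain that carries the charged nitrogen grows longer; the charged end and the rest of the molecule stay as they are.

The measured steps that touch this region are small. Changing the end of the chain gave a 1.7-fold higher number from compound 1 to compound 2 (0.22 log units; within the scatter) and a 2.0-fold higher number from compound 1 to compound 3 (0.30 log units; within the scatter); adding one carbon at the nitrogen gave a 1.2-fold higher number from compound 2 to compound 3 (0.08 log units; within the scatter). Among the compounds with values here, nothing measured yet varies the chain length itself, so the data give no direction for this step. The number for compound 4 is therefore expected to stay close to that of compound 3, with no change at the digits printed from compound 3 to compound 4 (within the scatter) meaning no step beyond the scatter. The estimate for compound 4 in this assay is 1200 nM, with a range from 500 nM to 3000 nM.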

Compound 4, half-maximal inhibitory concentration: 1400 nM
Estimate against measurement, compound 4: 1.2-fold (0.07 log units) below, within the range that was stated.
By their numbers in this assay, from the lowest: compounds 1, 2, 3 and 4 (each within the scatter of the next, the first and the last beyond it).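

Lengthening the chain that carries the charged nitrogen, with the group of 7 heavy atoms in place of the group of 4 heavy atoms, is the first variation of chain length here, and in this assay it gives a 1.2-fold higher number from compound 3 to compound 4 (0.07 log units; within the scatter). At this place, on a saturated chain carbon, three bonds along the chain from an oxygen on an aromatic ring, the longer group also stays close to the dimethylamino end of the shorter chain, with a 1.4-fold higher number from compound 2 to compound 4 (0.15 log units; within the scatter). Within the data shown here, the only step in the set to pass the scatter is a 2.3-fold higher number from compound 1 to compound 4 (0.37 log units; beyond the scatter), and it is modest; it replaces the hydroxy end and lengthens the chain in one move, so it cannot assign the difference to either change alone.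

Nothing available here offers an explanation for the size of any of these steps. Still open, going by these compounds, is how this assay responds to a much longer chain, or to a chain of this length ending in a carboxylic acid or a primary amine rather than the charged nitrogen group.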